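A few compounds are considered here, and "the series" means these few. Any claim that something is new, unique, unknown or untested is made for them only; others in the source may bear on it.

Measured compounds:
compound 1 `COc1ccc(C2OC(c3cc(OC)c(OC)c(OC)c3)=NN2C(C)=O)c(OC)c1` — 69.5%
compound 2 `COc1cc(C(=O)N/N=C/c2ccc(F)c(F)c2)cc(OC)c1OC` — 35.1%
compound 3 `COc1cc(C(=O)N/N=C/c2ccc(Cl)c(Cl)c2)cc(OC)c1OC` — 13.5%

In a functional assay on PC-3 cells (Homo sapiens) for antiproliferative activity, read by MTT assay, tested at 1 uM (on this read-out lower numbers stand for a weaker effect and higher numbers for a stronger effect at the one concentration tested), compound 1 gives 69.5%, the highest of the three numbers shown; compound 2 gives 35.1% and compound 3 gives 13.5%, each of them beyond the scatter below compound 1. Compound 4 `COc1ccc(OC)c(C2OC(c3cc(OC)c(OC)c(OC)c3)=NN2C(C)=O)c1` keeps the core of compound 1 and differs from it in one place: 2,5-dimethoxyphenyl in place of 2,4-dimethoxyphenyl on a saturated ring carbon. Among the measured compounds shown here, the single measured step, a number 21.6 percentage points lower from compound 2 to compound 3 (beyond the scatter), concerns an exchange of halogens on a different core, not the one shared by compound 1 and compound 4, so it offers no direct guidance. For the measured compounds named here, no measured pair shows what moving a methoxy group around the ring does on the shared core. With so little to go on, the expectation is that compound 4 stays near compound 1, most likely drifting somewhat lower, as the expected step of a number 14.5 percentage points lower from compound 1 to compound 4 (beyond the scatter) means, with a wide range of uncertainty. The estimate for compound 4 is therefore 55%, expected to lie between 30% and 75%.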

Compound 4, a percentage reported as inhibition, at one concentration (the size of the read-out at that concentration, not a potency): 37.2%
Compound 4: middle estimate off by 17.8 percentage points, on the high side; the measured number falls inside the stated range.
By their numbers in this assay, from the lowest: compound 3; then compounds 2 and 4 (each within the scatter of the next); then compound 1.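

Among the compounds shown here, putting 2,5-dimethoxyphenyl in place of 2,4-dimethoxyphenyl on the saturated ring carbon gives a number 32.3 percentage points lower from compound 1 to compound 4 (beyond the scatter) in this assay, and this is the first measured change on the shared core. The two groups have the same atoms and the same counted features, so the step shows that on this carbon the read-out depends on how the two methoxy groups are arranged on the aromatic ring, not merely on their presence. Nothing available here accounts for the size of this step, so the result stands as an observation without an explanation.

Two arrangements cannot show whether the difference follows from one methoxy group or from the pair acting together, and a plain phenyl group or a single methoxyphenyl group on the same carbon would help separate these possibilities. Going by these compounds, it also remains open whether the arrangement matters as much with a dimethylaminophenyl group on this carbon, or with a longer acyl chain such as propionyl in place of the acetyl group.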